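The compounds below may be only part of what the source reports. "The series", "measured", "known", "first", "only" and "open" are said of these compounds alone.

In a toxicity assay on THP-1 cells (Homo sapiens) for inhibition (a lower number here means that less compound is tolerated, a higher number that more compound is tolerated), compound 1 (`COc1ccc(-c2cnc(NC(=O)c3cnc[nH]3)n2C)cc1`) gives > 100000 nM as a limit of the assay, not a number. Compound 2 (`Cn1c(-c2ccccc2Cl)cnc1NC(=O)c1ncc[nH]1`) gives > 50000 nM as a limit too. Going by the values given here, compound 1 therefore has no measured number, and the series offers no measured step. Compound 3 (`COc1ccc(-c2cnc(NC(=O)c3cnco3)n2C)cc1`) carries 1,3-oxazol-5-yl in place of 1H-imidazol-5-yl on a carbonyl carbon. The expected change an at least 1.1-fold lower number from compound 1 to compound 3 (0.04 log units; that floor lies within the scatter) in this assay is none beyond the scatter. That expectation rests only on compound 1 and its limit of > 100000 nM as the starting point. Compound 3 is estimated at 90000 nM with an expected range from 30000 nM to 200000 nM as the working figures.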

Compound 3, half-maximal cytotoxic concentration: > 100000 nM
Compound 3 was reported as a limit; the forecaster's own chance of this, stated with the estimate: 70%; at least 1.1-fold (0.04 log units) between middle value and limit.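

In this assay, going by these compounds alone, compound 1 and compound 3 are both reported only as limits, so no step between them can be read. The compounds shown leave open at what concentration any of them reaches the half-maximal cytotoxic effect.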